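The source may hold more compounds than are shown below. What is called first, only, known or untested is meant among the compounds shown, and "the series" means these compounds.

Of the compounds shown here, two have so far been measured in a functional assay on A549 cells (Homo sapiens) for antiproliferative activity, read by MTT assay, with a stated time of 72 h; on this read-out higher numbers stand for weaker inhibition and lower numbers for stronger inhibition. Compound 1 `CC(C)(C)c1ccc(OCCCON2C(N)=NC(N)=NC23CCSCC3)cc1` gives 1 nM in this assay. Compound 2 `Cc1cc(C)cc(OCCCON2C(N)=NC(N)=NC23CCOCC3)c1` gives 710 nM in this assay, the higher of the two numbers and thus the weaker inhibitor of the pair; since compound 1 and compound 2 differ from each other in more than one place, their gap cannot be tied to any single change.

The compound still to be measured is compound 3 `Cc1ccc(OCCCON2C(N)=NC(N)=NC23CCOCC3)cc1`. Compared with compound 2, the change is 4-methylphenyl in place of 3,5-dimethylphenyl on an oxygen on a saturated carbon. For the measured compounds named here, no measured pair shows what such a change does here, so there is nothing to anchor a prediction. The step is expected to be small, a 1.3-fold higher number from compound 2 to compound 3 (0.10 log units; within the scatter), probably not beyond the scatter, with at most a slight drift toward weaker inhibition. Compound 3 is therefore estimated to give about 900 nM in this assay, within a range of 250 nM to 3500 nM.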

Compound 3, half-maximal inhibitory concentration: 1060 nM
Compound 3: middle estimate off by 1.2-fold (0.07 log units), on the low side; the range from low to high includes it.
By their numbers in this assay, from the lowest: compound 1; then compounds 2 and 3 (each within the scatter of the next).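

In this assay, for the compounds shown here, exchanging one substituted phenyl group for the other gives a 1.5-fold higher number from compound 2 to compound 3 (0.17 log units; within the scatter) and is the first change in this set that can be read on its own. At this position, with the rest of the molecule held fixed, the two groups cannot be told apart, though this rests on a single pair. The data at hand offer nothing that bears on why the two groups read alike.

As far as these compounds go, it remains open whether a different kind of group on the phenyl ring, such as an amine or a carboxylic acid, would shift the number beyond the scatter. A longer chain leading to this oxygen and the same exchange on a different core are also untested in the compounds shown.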